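Solubility at the Assay Ceiling for Three Amides

The compounds below may be only part of what the source reports. "The series", "measured", "known", "first", "only" and "open" are said of these compounds alone.

Three compounds sharing one core have been examined in a physicochemical assay for solubility, at pH 7; a lower number here means a less soluble compound, a higher number a more soluble compound: compound 1 `CC(=O)N1CCN(C(=O)N2Cc3c(NC(=O)c4ccc(F)cc4)n[nH]c3C2(C)C)CC1`, compound 3 `CN1CCN(C(=O)N2Cc3c(NC(=O)c4ccc(F)cc4)n[nH]c3C2(C)C)CC1` and compound 2 `CN1CCC(C(=O)N2Cc3c(NC(=O)C4CCC4)n[nH]c3C2(C)C)CC1`. Compound 1 reports only a limit of the assay, > 225000 nM. Compound 3 likewise reports only a limit, > 225000 nM. Compound 2 also stands at a limit rather than a number, > 225000 nM. For the measured compounds named here, the one single-place step among them, a step that the two limits leave unreadable from compound 1 to compound 3, is unreadable, since both of its ends sit at the limit of > 225000 nM in this assay, at which 3 of the 3 values shown sit.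

Compound 4 `CN1CCC(C(=O)N2Cc3c(NC(=O)c4ccc(C(F)(F)F)cc4)n[nH]c3C2(C)C)CC1` has not yet been measured. It differs from compound 2 by 4-(trifluoromethyl)phenyl in place of cyclobutyl on a carbonyl carbon. No measured step exchanges the group on this carbonyl carbon, so no shown step bears directly on it; the only pointer is that compound 1 and compound 3, the two measured compounds without a cyclobutyl group, also reach the limit. With compound 2 already at the ceiling, any change can only appear as a drop or as a repeat of the limit. Compound 4 is therefore expected near the ceiling, estimated at 150000 nM with a range from 30000 nM to 300000 nM. The step from compound 2 to compound 4 is estimated as an at least 1.5-fold lower number from compound 2 to compound 4 (0.17 log units; that floor lies within the scatter).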

Compound 4, solubility: 191000 nM
Compound 4: the middle estimate sits 1.3-fold (0.10 log units) below what was measured, and the stated range covers the measured number.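

For the compounds shown here, at this carbonyl carbon, whose other neighbour is an amide-type nitrogen, the exchange of cyclobutyl for 4-(trifluoromethyl)phenyl gives the first actual number in this set, with compound 4 at 191000 nM in this assay. Compound 2 holds only a limit of the assay, > 225000 nM. The exchange reads as an at least 1.1-fold lower number from compound 2 to compound 4 (0.07 log units; that floor lies within the scatter), so it is not shown to move the read-out and its true size stays unfixed, while the other step in the set cannot be read: the limit of > 225000 nM in this assay, at which 3 of the 4 values shown sit.

The compounds shown leave open how a carboxylic acid or a longer alkyl chain on this carbonyl carbon would read in this assay. Also open, going by these compounds, is whether 4-(trifluoromethyl)phenyl on this carbonyl carbon would read the same with acetyl in place of methyl on the amine nitrogen in the ring, the exchange whose step between compound 1 and compound 3 gives no size.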